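This account rests on a few compounds, and the source may have more. Where it says the series, first, only, none or still open, it means among the compounds named here.

Compound 1 `CC(C)(C)n1cc2c(n1)C(=O)CC1(CCN(C(=O)c3cc(-c4ccccc4)nc4ccccc34)CC1)O2`: 1940 nM
Compound 2 `Cc1ccccc1-c1cc(C(=O)N2CCC3(CC2)CC(=O)c2nn(C(C)(C)C)cc2O3)c2ccccc2n1`: 1880 nM
Compound 3 `CC(C)(C)n1cc2c(n1)C(=O)CC1(CCN(C(=O)c3cc(-c4ccc(F)cc4)nc4ccccc34)CC1)O2`: 5770 nM

In a functional assay on A549 cells (Homo sapiens) for inhibition, read by MTT assay, with a stated time of 72 h (a higher number here means a weaker inhibitor, a lower number a stronger inhibitor), compound 2 stands level with compound 1, at a 1.0-fold lower number from compound 1 to compound 2 (0.01 log units; within the scatter), and both sit clearly below compound 3. Compound 4 `CC(C)(C)n1cc2c(n1)C(=O)CC1(CCN(C(=O)c3cc(-c4ccc(Br)cc4)nc4ccccc34)CC1)O2` has 4-bromophenyl in place of 2-methylphenyl on an aromatic carbon. The closest guide is a 3.1-fold higher number from compound 2 to compound 3 (0.49 log units; beyond the scatter), where 4-fluorophenyl enters instead. Adding fluoro to compound 1 gave a similar rise, a 3.0-fold higher number from compound 1 to compound 3 (0.47 log units; beyond the scatter). Within the data shown here, no bromo compound has been measured, so these steps are only a rough guide. A modest rise is therefore expected, meaning a weaker inhibitor, and the estimated step is a 2.1-fold higher number from compound 2 to compound 4 (0.33 log units; beyond the scatter). For compound 4 the expected value is 4000 nM, with an estimated range of 1500 nM to 10500 nM.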

Compound 4, half-maximal inhibitory concentration: 9300 nM
For compound 4 the middle estimate is 2.3-fold (0.37 log units) below the measured one; low and high end bracket the measured number.
By their numbers in this assay, from the lowest: compounds 2 and 1 (each within the scatter of the next); then compounds 3 and 4 (each within the scatter of the next).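

In this assay, the two halogens cannot be told apart: bromo in place of fluoro gives a 1.6-fold higher number from compound 3 to compound 4 (0.21 log units; within the scatter). The rise seen with 4-fluorophenyl holds with 4-bromophenyl, at a 4.8-fold higher number from compound 1 to compound 4 (0.68 log units; beyond the scatter) and a 4.9-fold higher number from compound 2 to compound 4 (0.69 log units; beyond the scatter), so both halogen-bearing rings go with a weaker inhibitor than phenyl or 2-methylphenyl. No measurement here explains this. Going by these compounds, whether a ring carrying an amine or a methoxy group at the same spot as the halogens would match phenyl stays open, as does the effect of replacing the phenyl ring with a pyridine ring.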